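Swapping methyl for bromo on a shared core

The source may hold more compounds than are shown below. What is called first, only, known or untested is meant among the compounds shown, and "the series" means these compounds.

Compound 1 `C=CC(=O)N1C(=O)CC(c2ccc(C)cc2)Sc2ccccc21` gives 37300 nM in a functional assay on NB-4 cells (Homo sapiens) for cytotoxicity, read by CCK-8 assay, with a stated time of 24 h; a higher number here means a weaker inhibitor, a lower number a stronger inhibitor.
Compound 2 `C=CC(=O)N1C(=O)CC(c2cccc(Cl)c2)Sc2ccccc21` gives 31700 nM.
Compound 3 `C=CC(=O)N1C(=O)CC(c2ccc(C(=O)OC)cc2)Sc2ccccc21` gives 24400 nM.

Compound 1 has the highest of the three numbers, yet compound 2 and compound 3 both lie within the scatter of it, so the three cannot be told apart. Compound 4 `C=CC(=O)N1C(=O)CC(c2ccc(Br)cc2)Sc2ccccc21` differs from compound 1 by bromo in place of methyl on an aromatic carbon. Two measured steps from compound 1 bear on this change, both on the same ring: a 1.2-fold lower number from compound 1 to compound 2 (0.07 log units; within the scatter) and a 1.5-fold lower number from compound 1 to compound 3 (0.18 log units; within the scatter). Neither reached beyond the scatter, so the step to compound 4 is expected to stay within the scatter too, a 1.2-fold lower number from compound 1 to compound 4 (0.09 log units; within the scatter). Compound 4 is therefore estimated at 30000 nM, in a range from 15000 nM to 60000 nM.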

Compound 4, half-maximal inhibitory concentration: 59400 nM
Compound 4: the middle estimate sits 2.0-fold (0.30 log units) below what was measured; low and high end bracket the measured number.
By their numbers in this assay, from the lowest: compounds 3, 2, 1 and 4 (each within the scatter of the next, the first and the last beyond it).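

Bromo in place of methyl gives a 1.6-fold higher number from compound 1 to compound 4 (0.20 log units; within the scatter) and, against the other halogen compound, the change gives a 1.9-fold higher number from compound 2 to compound 4 (0.27 log units; within the scatter). Only the comparison with the ester clears the scatter, with a 2.4-fold higher number from compound 3 to compound 4 (0.39 log units; beyond the scatter), so this aromatic carbon now shows a first, modest separation between two of its groups. Nothing shown explains that gap. On these data alone, whether an amine or a carboxylic acid on this carbon would widen the gap remains open. So does whether the gap between bromo and methoxycarbonyl would hold on other cells.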